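Second chloro on the core of compound 1

The source may hold more compounds than are shown below. What is called first, only, known or untested is meant among the compounds shown, and "the series" means these compounds.

Compound 1 `ClCc1ccc(Cn2cnc3c(Cl)ncnc32)cc1` gives, in a functional assay on DU-145 cells (Homo sapiens) for cytotoxicity, read by sulforhodamine B assay, with a stated time of 48 h (on this read-out higher numbers stand for lower toxicity in this test and lower numbers for higher toxicity in this test), a value of 36300 nM, the higher of the two numbers at hand. Compound 2 `ClCc1ccccc1Cn1cnc2ncnc(Cl)c21` gives in this assay 33100 nM; the two values lie within the scatter of each other, so no order is read from them. Compound 3 `ClCc1ccc(Cn2cnc3c(Cl)nc(Cl)nc32)cc1` differs from compound 1 by chloro in place of hydrogen on an aromatic carbon. Within the data shown here, no measured pair shows this change, so the size of the step is unknown; a step near the scatter, in either direction, is expected. Compound 3 is therefore estimated at 26000 nM, between 8000 nM and 80000 nM, an expected step of a 1.4-fold lower number from compound 1 to compound 3 (0.14 log units; within the scatter) from compound 1.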

Compound 3, concentration lethal to 50% of the cells: 42700 nM
Estimate against measurement, compound 3: 1.6-fold (0.22 log units) below; low and high end bracket the measured number.
By their numbers in this assay, from the lowest: compounds 2, 1 and 3 (each within the scatter of the next).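

Chloro in place of hydrogen on the aromatic carbon between two ring nitrogen atoms gives the first pair in the series that differs in one place, and in this assay the step is small (a 1.2-fold higher number from compound 1 to compound 3 (0.07 log units; within the scatter)). On this single pair, the position takes a chloro group with no change that can be told from the scatter. No measurement at hand bears on this result.

As far as these compounds go, whether an amine or a methoxy group on this carbon would move the number away from compound 1 stays open. So does whether the same chloro change on compound 2 would also stay within the scatter.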